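Chain shortening and amide change on the shared core

The source may hold more compounds than are shown below. What is called first, only, known or untested is meant among the compounds shown, and "the series" means these compounds.

Compound 2 `O=C(NCCCNc1nccc(-c2c(-c3cccc(F)c3)nc3sccn23)n1)c1ccc(F)cc1` gives 14900 nM in a functional assay on A-375 cells (Homo sapiens) for cytotoxicity, read by MTT assay (a lower number here means a stronger inhibitor, a higher number a weaker inhibitor), the highest of the three numbers measured. Compound 1 `Cc1ccc(S(=O)(=O)NCCCNc2nccc(-c3c(-c4cccc(F)c4)nc4sccn34)n2)cc1` gives 8380 nM in this assay, and the step of a 1.8-fold higher number from compound 1 to compound 2 (0.25 log units; within the scatter) stays inside the scatter. Compound 3 `O=C(NCCNc1nccc(-c2c(-c3cccc(F)c3)nc3sccn23)n1)c1ccccc1` gives 5060 nM; the step of a 2.9-fold lower number from compound 2 to compound 3 (0.47 log units; beyond the scatter) is the only one beyond the scatter, while the step of a 1.7-fold lower number from compound 1 to compound 3 (0.22 log units; within the scatter) is not.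

Compound 4 `O=C(NCCNc1nccc(-c2c(-c3cccc(F)c3)nc3sccn23)n1)c1c(F)cccc1F` has not been measured. It differs from compound 2 in one place: ((2,6-difluorophenyl)carbonyl)amino in place of (((4-fluorophenyl)carbonyl)amino)methyl on a saturated chain carbon, two bonds along the chain from a nitrogen on an aromatic ring. The change thus pairs the same shortening of the linker seen in the step from compound 2 to compound 3 with a (2,6-difluorophenyl)carbonyl in place of the (4-fluorophenyl)carbonyl. The measured step bearing on it is a 2.9-fold lower number from compound 2 to compound 3 (0.47 log units; beyond the scatter); nothing measured separates the effect of the fluorine pattern on the amide ring from that of the linker length. A modest lowering of the number is therefore expected, of the order of a 2.5-fold lower number from compound 2 to compound 4 (0.40 log units; beyond the scatter). Compound 4 is estimated at 6000 nM in this assay, with a range of 2500 nM to 14000 nM.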

Compound 4, half-maximal inhibitory concentration: 2700 nM
The estimate for compound 4 lay 2.2-fold (0.35 log units) above the measured number; low and high end bracket the measured number.
By their numbers in this assay, from the lowest: compounds 4, 3, 1 and 2 (each within the scatter of the next, the first and the last beyond it).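

Among the compounds shown here, with the chain held as in compound 3, 2,6-difluorophenyl in place of phenyl on the carbonyl carbon gives a 1.9-fold lower number from compound 3 to compound 4 (0.27 log units; within the scatter) in this assay, so the fluorines alone produce no step distinguishable from scatter. For the compounds shown here, compound 4 is the only compound here whose step from compound 1 is beyond the scatter, at a 3.1-fold lower number from compound 1 to compound 4 (0.49 log units; beyond the scatter), and the widest step is a 5.5-fold lower number from compound 2 to compound 4 (0.74 log units; beyond the scatter), although both steps change the chain and the capping group together. No measured information is available to explain these steps.

Going by these compounds, it remains open whether the (2,6-difluorophenyl)carbonyl group would give a comparable number on the longer chain of compound 2. On these data alone, how an amine or a carboxylic acid would read in place of the amide at this position is also open.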